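The source may hold more compounds than are shown below. What is called first, only, known or untested is meant among the compounds shown, and "the series" means these compounds.

Compound 1 `O=C(/C=C/c1ccccc1)NS(=O)(=O)c1ccc(Br)cc1`: 3.9 ug/mL
Compound 2 `O=C(/C=C/c1ccc(Br)cc1)NS(=O)(=O)c1ccc(Br)cc1`: 5.1 ug/mL
Compound 3 `COc1ccc(/C=C/C(=O)NS(=O)(=O)c2ccc(Br)cc2)cc1`: 5.8 ug/mL

In a functional assay on B16-F10 cells (Mus musculus) for antiproliferative activity, read by ELISA and MTT assay, with a stated time of 48 h (on this read-out lower numbers stand for stronger inhibition and higher numbers for weaker inhibition), compound 1 stands at the lowest of the three numbers, yet its distance to either neighbour stays within the scatter, so the three compounds cannot be ranked. Compound 4 `O=C(/C=C/c1ccccc1[N+](=O)[O-])NS(=O)(=O)c1ccc(Br)cc1` differs from compound 1 by nitro in place of hydrogen on an aromatic carbon. Going by the values given here, the steps that bear on this change are a 1.3-fold higher number from compound 1 to compound 2 (0.12 log units; within the scatter) and a 1.5-fold higher number from compound 1 to compound 3 (0.17 log units; within the scatter): each adds a group to the same ring where compound 1 carries only hydrogen, and neither moves the number beyond the scatter. No nitro group and no substituent ortho to a large group has been measured here. Compound 4 is therefore expected to sit close to compound 1, as a 1.3-fold higher number from compound 1 to compound 4 (0.11 log units; within the scatter), with an estimate of 5 ug/mL ranging from 2.5 ug/mL to 10 ug/mL.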

Compound 4, half-maximal inhibitory concentration: 12.6 ug/mL
Compound 4: middle estimate off by 2.5-fold (0.40 log units), on the low side; measured number above the stated range.
By their numbers in this assay, from the lowest: compounds 1, 2 and 3 (each within the scatter of the next); then compound 4.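

In this assay, going by these compounds alone, nitro ortho to a large group gives a 3.2-fold higher number from compound 1 to compound 4 (0.51 log units; beyond the scatter) and so is the first change on this ring to lie beyond the scatter, with weaker inhibition than compound 1, whereas the bromo and methoxy steps stayed within it. Compound 4 differs from compounds 2 and 3 in both the group and its place, so the two effects cannot be separated. Nothing shown here accounts for this step. As far as these compounds go, it remains open whether an amine or a carboxylic acid in that same place would give a similar step, and whether nitro would do so elsewhere on this ring.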